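The source may hold more compounds than are shown below. What is called first, only, known or untested is meant among the compounds shown, and "the series" means these compounds.

In a functional assay on Caco-2 cells (Homo sapiens) for inhibition, read by MTT assay, with a stated time of 48 h, tested at 10 uM (a lower number here means less inhibition of growth, a higher number more inhibition of growth at the concentration tested), compound 1 `Cc1oc2c([C@H]3CCN(C)C[C@H]3O)c(O)cc(O)c2c(=O)c1C(O)c1cccc(Cl)c1` gives 4% and compound 2 `Cc1oc2c([C@H]3CCN(C)C[C@H]3O)c(O)cc(O)c2c(=O)c1C(O)c1csc([N+](=O)[O-])c1` gives 3%, so these two sit within the scatter of each other and compound 2 does not stand apart. Compound 3 `CCOc1ccc(Br)c(C(O)c2c(C)oc3c([C@H]4CCN(C)C[C@H]4O)c(O)cc(O)c3c2=O)c1` keeps the shared core and differs from compound 2 in one group: 2-bromo-5-ethoxyphenyl in place of 5-nitrothiophen-3-yl on a saturated chain carbon bound to an aromatic carbon and an oxygen on a saturated carbon. Among the compounds with values here, only one measured step bears on this, a swap at the same place, a number 1 percentage points lower from compound 1 to compound 2 (within the scatter), and it stayed within the scatter. No change beyond the scatter is therefore expected in this assay, with an estimated a number 3 percentage points higher from compound 2 to compound 3 (within the scatter). For compound 3 the estimated value is 6%, with an expected range of 0% to 18%.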

Compound 3, percent growth inhibition at one concentration: 5%
Estimate against measurement, compound 3: 1 percentage points above; measured number inside the range.
By their numbers in this assay, from the lowest: compounds 2, 1 and 3 (each within the scatter of the next).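

In this assay, swapping in 2-bromo-5-ethoxyphenyl gives a number 2 percentage points higher from compound 2 to compound 3 (within the scatter) and a number 1 percentage points higher from compound 1 to compound 3 (within the scatter), so neither step can be told apart from no change. At this carbon, a bromo- and ethoxy-bearing phenyl ring, a chlorophenyl ring and a nitrothiophene ring all leave growth inhibition at the same low level among these three compounds. Nothing measured here explains this result. All three groups at this place are aromatic rings, so an amine, a carboxylic acid or a longer alkyl chain there remains untested in the compounds shown. Going by these compounds, whether any change elsewhere on the shared core would raise the number also stays open.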